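A few compounds are considered here, and "the series" means these few. Any claim that something is new, unique, unknown or untested is made for them only; others in the source may bear on it.

Measured so far:
- compound 1, `CCN(Cc1cccs1)C(=O)C(C)Oc1ccc(C)cc1`: 889 nM
- compound 2, `CCN(Cc1cccn1C)C(=O)COc1ccc(C)cc1`: 21300 nM
- compound 3, `Cc1ccc(OCC(=O)N(Cc2cccs2)C2CCCCC2)cc1`: 40000 nM

All three were tested in an assay on HEK293 cells for agonist activity at transient receptor potential cation channel subfamily M member 8 (Homo sapiens), read by fluorescence and calcium flux, with a stated time of 15 min; on this read-out higher numbers stand for an effect only at larger amounts of compound and lower numbers for an effect already at smaller amounts. Compound 2 gives 21300 nM, the second highest of the three numbers. Its nearest neighbour is compound 3 at 40000 nM, a gap within the usual scatter, so the two cannot be told apart. Compound 1 lies furthest away at 889 nM, a gap well beyond the scatter.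

Compound 4, `CCN(Cc1ccsc1)C(=O)COc1ccc(C)cc1`, has not yet been measured in this assay. It differs from compound 2 in one place: thiophen-3-yl in place of 1-methyl-1H-pyrrol-2-yl on a saturated chain carbon bound to an amide-type nitrogen. Among the compounds with values here, compound 1 and compound 3 differ from compound 4 in more than one place, so neither offers a clean comparison, and no single-change step among the measured compounds guides this change. Still, compound 1 shows that a much lower number is reachable in this series because of 889 nM. The step from compound 2 to compound 4 is therefore expected to be a moderate move towards lower numbers, a 3.6-fold lower number from compound 2 to compound 4 (0.55 log units; beyond the scatter), though a result within the scatter of compound 2 would not be surprising. Compound 4 is estimated to give 6000 nM, with a likely range from 1200 nM to 30000 nM.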

Compound 4, half-maximal effective concentration: 88 nM
Compound 4: middle estimate off by 68-fold (1.83 log units), on the high side; the whole stated range lies above it.
By their numbers in this assay, from the lowest: compound 4; then compound 1; then compounds 2 and 3 (each within the scatter of the next).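

In this assay, putting thiophen-3-yl in place of 1-methyl-1H-pyrrol-2-yl on a saturated chain carbon bound to an amide-type nitrogen gives a 240-fold lower number from compound 2 to compound 4 (2.38 log units; beyond the scatter), so the number at this place depends strongly on which ring is attached. The step is large even though both groups are five-membered aromatic rings with 1 hetero atom, and they match in hydrogen-bond donors, hydrogen-bond acceptors and net charge. No supporting measurement is available to explain why this exchange matters so much.

The compounds shown cannot separate the effect of exchanging the hetero atom from that of changing where the ring is attached. As far as these compounds go, it also remains open how a furan-3-yl or a phenyl ring would behave at this same place on the shared core.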